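Shortening the Chain of Compound 1

A few compounds are considered here, and "the series" means these few. Any claim that something is new, unique, unknown or untested is made for them only; others in the source may bear on it.

In a functional assay on PC-3 cells (Homo sapiens) for inhibition, read by MTT assay, with stated times of 18 h and 4 h (a lower number here means a stronger inhibitor, a higher number a weaker inhibitor), compound 1 (`CCCCCCCCCCOP(=O)(O)OCCSC(=S)N1CCCCCC1`) gives 32900 nM. Compound 2 (`CCCCCCCCCCOP(=O)(O)OCCSC(=S)N1CCCC1`) gives 56100 nM, and a 1.7-fold higher number from compound 1 to compound 2 (0.23 log units; within the scatter) stays within the scatter. Compound 3 (`CCCCCCCCCCOP(=O)(O)OCCSC(=S)N1CCN(C)CC1`) gives 80000 nM, and a 2.4-fold higher number from compound 1 to compound 3 (0.39 log units; beyond the scatter) is modest, so compound 1 stands clear of compound 3 only. Compound 4 (`CCCCCCCCOP(=O)(O)OCCSC(=S)N1CCCCCC1`) keeps the azepan-1-yl group of compound 1 and shortens the chain: hydrogen in place of ethyl on a saturated chain carbon, eight bonds along the chain from an oxygen on an unsaturated carbon. Going by the values given here, all the measured steps swap the group on the thiocarbonyl carbon and none touches the chain, so they offer only a rough guide to size. A modest move to a higher number is expected, as a 2.1-fold higher number from compound 1 to compound 4 (0.33 log units; beyond the scatter) in this estimate. For compound 4 the estimated value is 70000 nM, with an expected range of 35000 nM to 140000 nM.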

Compound 4, half-maximal inhibitory concentration: 56800 nM
Compound 4: middle estimate off by 1.2-fold (0.09 log units), on the high side; low and high end bracket the measured number.
By their numbers in this assay, from the lowest: compounds 1, 2, 4 and 3 (each within the scatter of the next, the first and the last beyond it).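

Going by these compounds alone, the chain itself changes here for the first time: in this assay, the step gives a 1.7-fold higher number from compound 1 to compound 4 (0.24 log units; within the scatter), for hydrogen in place of ethyl on a saturated chain carbon, eight bonds along the chain from an oxygen on an unsaturated carbon. At this position, then, compound 4 cannot be told apart from compound 1 in this assay. Nothing measured here explains this result.

On these data alone, whether a longer chain would likewise stay within the scatter remains open. So does the effect of placing an amine or a carboxylic acid at this chain position.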